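Pyrrolidin-1-yl in place of dimethylamino: working notes

A few compounds are considered here, and "the series" means these few. Any claim that something is new, unique, unknown or untested is made for them only; others in the source may bear on it.

Compound 1 `COc1cc(NC(C)CCCNC(c2ccc(CO[C@@H]3COc4nc([N+](=O)[O-])cn4C3)cc2)c2nnnn2C(C)(C)C)c2ncccc2c1` gives 75900 nM as measured
Compound 2 `CN(C)C(c1ccc(CO[C@@H]2COc3nc([N+](=O)[O-])cn3C2)cc1)c1nnnn1C(C)(C)C` gives 177000 nM as measured

In an ADME assay on L6 cells (Rattus norvegicus) for cytotoxicity, read by fluorescence, with a stated time of 72 h (a lower number here means a stronger inhibitor, a higher number a weaker inhibitor), compound 2 stands highest of the two at 177000 nM and compound 1 lies lower, beyond the scatter. Compound 3 `CC(C)(C)n1nnnc1C(c1ccc(CO[C@@H]2COc3nc([N+](=O)[O-])cn3C2)cc1)N1CCCC1` is compound 2 with one change pyrrolidin-1-yl in place of dimethylamino on a saturated chain carbon bound to two aromatic carbons that puts pyrrolidin-1-yl in place of dimethylamino on a saturated chain carbon bound to two aromatic carbons. Within the data shown here, no measured pair shows this change, and no step beyond the scatter is expected in this assay from it. The estimated 1.2-fold lower number from compound 2 to compound 3 (0.07 log units; within the scatter) is expected to stay within the scatter. Compound 3 is estimated at 150000 nM with an expected range from 70000 nM to 300000 nM for the coming measurement.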

Compound 3, half-maximal inhibitory concentration: 75200 nM
Compound 3: the middle estimate sits 2.0-fold (0.30 log units) above what was measured; low and high end bracket the measured number.
By their numbers in this assay, from the lowest: compounds 3 and 1 (each within the scatter of the next); then compound 2.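

In this assay, among these compounds, pyrrolidin-1-yl in place of dimethylamino on a saturated chain carbon bound to two aromatic carbons gives a 2.4-fold lower number from compound 2 to compound 3 (0.37 log units; beyond the scatter) and is the first single-place step read at this position. The number therefore moves with this one substitution, although the step is modest. Nothing available explains the step.

A single pair cannot separate the effect of the ring from that of the added carbons. Diethylamino or piperidin-1-yl at this place would show whether the step holds beyond this pair.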